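Pyridin-2-yl replacing tert-butyl in a fused pyrazolone series

The source may report more compounds than this note shows. Statements on the series, on what has been measured and on what is new or still open speak of the compounds shown alone.

Of the compounds shown here, three of the shared core have been measured in an assay on isolated protein for inhibition of MAP kinase-activated protein kinase 5 (Homo sapiens), read by mobility shift assay, tested at 30 uM; on this read-out lower numbers stand for less inhibition and higher numbers for more inhibition at the one concentration tested (going by the name of the read-out). Compound 1 `Cc1cc2c(c(N)nn2C)c(=O)[nH]1` gives 5% in this assay. Compound 2 `COCCNc1nc(-c2ccccc2)cc2c1c(N)nn2C` gives 1% in this assay. Compound 3 `CC(C)(C)c1cc2nn(-c3ccccc3)c(N)c2c(=O)[nH]1` gives 2% in this assay. Among these three numbers compound 3 sits with compound 2 nearest to it and compound 1 furthest, and none of these gaps exceeds the usual scatter of repeated measurements, so the three compounds are indistinguishable on this read-out.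

Compound 4 `Nc1c2c(=O)[nH]c(-c3ccccn3)cc2nn1-c1ccccc1` is not yet measured. It differs from compound 3 in one place: pyridin-2-yl in place of tert-butyl on an aromatic carbon. For the measured compounds named here, no step between measured compounds is available that isolates this kind of change, so nothing so far speaks for a shift in either direction. Given that compound 3 gives 2% and all three measured compounds cluster at low inhibition, the step of a number 2 percentage points higher from compound 3 to compound 4 (within the scatter) is expected to lie within the scatter. Compound 4 is therefore estimated at 4% in this assay, with a plausible range from -5% to 15%.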

Compound 4, a percentage reported as inhibition, at one concentration (the size of the read-out at that concentration, not a potency): 2%
For compound 4 the middle estimate is 2 percentage points above the measured one, within the range that was stated.
By their numbers in this assay, from the lowest: compounds 2, 3, 4 and 1 (each within the scatter of the next).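

In this assay, for the compounds shown here, pyridin-2-yl in place of tert-butyl on the aromatic carbon next to the ring nitrogen gives no change at the digits printed from compound 3 to compound 4 (within the scatter), the first step that isolates a single change. This position therefore accepts an aromatic ring with one hetero atom and a hydrogen-bond acceptor in place of a group with no ring, with no difference on this read-out, although compound 3 and compound 4 both stay at low inhibition, so the step cannot show whether this position has any influence on this assay. No evidence on hand explains this result.

On these data alone, whether a carboxylic acid, an amine or a longer chain on this carbon would bring inhibition clear of the scatter remains open. Also open, as far as these compounds go, is whether a group other than phenyl on the ring nitrogen would change how this position reads.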